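Methoxy on the aryl ring of compound 3

This account rests on a few compounds, and the source may have more. Where it says the series, first, only, none or still open, it means among the compounds named here.

This account follows one change within a small set of three aryl ethers that share a thiazole amide. In a functional assay on Ehrlich cells (Mus musculus) for cytotoxicity, read by trypan blue exclusion, with a stated time of 48 h (on this read-out lower numbers stand for stronger inhibition and higher numbers for weaker inhibition), compound 1 `COc1ccc(-c2csc(NC(=O)COc3ccc(C(=O)c4ccccc4)cc3C)n2)cc1` gives 27100 nM, compound 2 `COc1ccc(-c2csc(NC(=O)COc3ccc(C(=O)c4ccc(C)cc4)cc3C)n2)cc1` gives 19400 nM, and compound 3 `Cc1cc(C(=O)c2cccc(Br)c2)ccc1OCC(=O)Nc1nc(-c2ccccc2)cs1` gives 24300 nM. Compound 3 sits second highest of the three numbers, but its gaps to compound 1 and to compound 2 both lie within the scatter, so the three cannot be told apart. Compound 4 `COc1ccc(-c2csc(NC(=O)COc3ccc(C(=O)c4cccc(Br)c4)cc3C)n2)cc1` differs from compound 3 by methoxy in place of hydrogen on an aromatic carbon. Going by the values given here, the only measured step that bears on it is a 1.4-fold lower number from compound 1 to compound 2 (0.15 log units; within the scatter), a small change on a different aromatic ring that left the number within the scatter; no measured pair shows a methoxy entering or leaving at this place. From this, compound 4 is expected to stay close to compound 3, with a step of a 1.1-fold lower number from compound 3 to compound 4 (0.04 log units; within the scatter) and no change beyond the scatter. Compound 4 is therefore estimated at 22000 nM, within a range from 11000 nM to 45000 nM.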

Compound 4, half-maximal inhibitory concentration: 38100 nM
Compound 4: middle estimate off by 1.7-fold (0.24 log units), on the low side; low and high end bracket the measured number.
By their numbers in this assay, from the lowest: compounds 2, 3, 1 and 4 (each within the scatter of the next).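

In this assay, the difference from phenyl to 4-methoxyphenyl now has a measured pair (see a 1.6-fold higher number from compound 3 to compound 4 (0.20 log units; within the scatter)), and methoxy at this place, para to a large group, does not shift the number beyond the scatter. The ring on the carbonyl carbon gives the same reading with the methoxy in place, both for bromo in place of hydrogen (see a 1.4-fold higher number from compound 1 to compound 4 (0.15 log units; within the scatter)) and for 3-bromophenyl in place of 4-methylphenyl (see a 2.0-fold higher number from compound 2 to compound 4 (0.29 log units; within the scatter)). Nothing measured on these compounds offers an explanation of these numbers.

The four compounds therefore remain indistinguishable step by step, and no change among them yet marks this position as one that moves the number. From the compounds shown here alone, whether an amine, a carboxylic acid or a longer chain at this place would do so remains open.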